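The source may hold more compounds than are shown below. What is called first, only, known or untested is meant among the compounds shown, and "the series" means these compounds.

Working notes on the series. In a functional assay on U-251 cells (Homo sapiens) for inhibition, read by MTT assay, with a stated time of 2 days (on this read-out lower numbers stand for stronger inhibition of growth and higher numbers for weaker inhibition of growth), compound 1 (`Nc1ccccc1NC(=O)CCCNCC(=O)Nc1ccc(Br)cc1`) gives 80000 nM, compound 2 (`Nc1ccccc1NC(=O)c1ccc(NCC(=O)Nc2ccc([N+](=O)[O-])cc2)cc1`) gives 42500 nM and compound 3 (`Nc1ccccc1NC(=O)c1ccc(NCC(=O)Nc2cccc([N+](=O)[O-])c2)cc1`) gives 52000 nM. Compound 1 thus stands within the scatter of both others, and the three numbers set up no order.

The next compound is compound 4 (`Nc1ccccc1NC(=O)CCCNCC(=O)Nc1cc(Cl)ccc1Cl`), with 2,5-dichlorophenyl in place of 4-bromophenyl on an amide-type nitrogen.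

Within the data shown here, one measured step bears on this, as it also changes the aryl group on an amide-type nitrogen: a 1.2-fold higher number from compound 2 to compound 3 (0.09 log units; within the scatter). That step stays within the scatter, but it sits on a core different from that of compound 1, so it is only a weak guide. Among the measured compounds shown here, no measured step exchanges bromine for chlorine.

No change beyond the scatter is therefore expected in this assay. The estimated step is small, a 1.1-fold lower number from compound 1 to compound 4 (0.06 log units; within the scatter), in no firm direction. For compound 4 the expected value is 70000 nM, with an estimated range of 35000 nM to 130000 nM.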

Compound 4, concentration for total growth inhibition: > 100000 nM
Compound 4 gave a limit, no number (the forecaster's own chance of this, stated with the estimate: 15%); at least 1.4-fold (0.15 log units) between middle value and limit.
By their numbers in this assay, from the lowest: compounds 2, 3 and 1 (each within the scatter of the next). At a limit, above all of these: compound 4.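

In this assay compound 4 gives a limit of the assay and not a number: the limit of > 100000 nM in this assay, at which 1 of the 4 values shown sits. On the core of compound 1, 2,5-dichlorophenyl in place of 4-bromophenyl on an amide-type nitrogen gives an at least 1.2-fold higher number from compound 1 to compound 4 (0.09 log units; that floor lies within the scatter), and this is the first step shown that changes the aryl group on that core. The limit excludes any gain in growth inhibition from this change, but the floor of the step stays within the scatter, so a real loss is not established.

Going by these compounds, the true size of the step remains open, as does the separate contribution of exchanging bromine for chlorine and of the two chlorine atoms. Also open, on these data alone, is how this core would respond to a phenyl ring carrying an amine or a carboxylic acid on the amide-type nitrogen.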